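Changing the ring-nitrogen substituent in an alkyne series

A few compounds are considered here, and "the series" means these few. Any claim that something is new, unique, unknown or untested is made for them only; others in the source may bear on it.

Measured so far in an assay on HEK293 cells for displacement of a labelled ligand from metabotropic glutamate receptor 5 (Homo sapiens), with a stated time of 2 h; a higher number here means a weaker inhibitor, a lower number a stronger inhibitor:
Compound 1, `CC(C)N1CCc2nc(C#Cc3ccccc3)ccc2C1=O`, gives 1280 nM.
Compound 2, `Cc1cccc(C#Cc2ccc3c(n2)CCN(C(C)C)C3=O)c1`, gives 510 nM.
Compound 3, `CC(C)N1CCc2nc(C#Cc3cccnc3)ccc2C1=O`, gives 19600 nM.

Among these three numbers compound 1 stands second highest. Its nearest neighbour is compound 2: the move is a modest one, a 2.5-fold lower number from compound 1 to compound 2 (0.40 log units; beyond the scatter). Its furthest neighbour is compound 3, a large move, a 15-fold higher number from compound 1 to compound 3 (1.19 log units; beyond the scatter). The two outer compounds are separated by an even larger step, a 38-fold higher number from compound 2 to compound 3 (1.58 log units; beyond the scatter).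

Compound 4, `O=C1c2ccc(C#Cc3ccccc3)nc2CCN1C1CCCCC1`, has not yet been measured. It differs from compound 1 in one place: cyclohexyl in place of isopropyl on an amide-type nitrogen in a ring. Within the data shown here, every measured step so far alters the aromatic group at the far end of the triple bond; none of them changes the group on the amide-type nitrogen in the ring. The three numbers in hand therefore say nothing direct about the step from compound 1 to compound 4, and any expectation has to be loose. Among the measured compounds shown here, with no step to lean on, the expected outcome for compound 4 is a 1.1-fold lower number from compound 1 to compound 4 (0.03 log units; within the scatter), that is, no step beyond the scatter in either direction. Compound 4 is estimated to give about 1200 nM in this assay, with a range from 250 nM to 6000 nM.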

Compound 4, inhibition constant: 12400 nM
Beside the measured number, compound 4's estimate is 10-fold (1.01 log units) below it; the whole stated range lies below it.
By their numbers in this assay, from the lowest: compound 2; then compound 1; then compounds 4 and 3 (each within the scatter of the next).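

The group on the amide-type nitrogen in the ring turns out to matter: in this assay, putting cyclohexyl in place of isopropyl gives a 9.7-fold higher number from compound 1 to compound 4 (0.99 log units; beyond the scatter), so the inhibitor becomes weaker. Among these compounds, every earlier step changed the aromatic group at the far end of the triple bond, so this is the first sign that the number also responds to a change at this nitrogen, and here the group with more heavy atoms and a ring of carbon gives the weaker compound. Nothing available here explains why this single change has an effect of this size.

This one pair cannot show whether the ring itself or simply the greater number of carbons goes with the weaker binding, and methyl, cyclopropyl or an open hexyl chain on the same nitrogen would bear on that question. Also open, as far as these compounds go, is whether cyclohexyl would have a similar effect with the 3-methylphenyl group of compound 2 in place of the phenyl group.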